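This account rests on a few compounds, and the source may have more. Where it says the series, first, only, none or still open, it means among the compounds named here.

Compound 1 `Cn1nc(CN2CCCC2)nc1-c1ccc(C2CC2)cc1`: 1000 nM
Compound 2 `Cn1nc(CN2CCCC2)nc1-c1cccc(Oc2ccccc2)c1`: > 1000 nM

Among the measured compounds shown here, in an assay on membranes from Jurkat cells for displacement of a labelled ligand from Sigma intracellular receptor 2 (Homo sapiens), read by scintillation counting, with a stated time of 1 h (on this read-out higher numbers stand for weaker inhibition and lower numbers for stronger inhibition), compound 1 gives 1000 nM, the only plain number in this set. Compound 2 reaches only > 1000 nM, a limit of the assay and not a number; this is the limit of > 1000 nM in this assay, at which 1 of the 2 values shown sits. Compound 3 `Cn1nc(CN2CCCC2)nc1-c1ccc(C(F)(F)F)cc1` carries trifluoromethyl in place of cyclopropyl on an aromatic carbon. For the measured compounds named here, no measured pair of this kind exists, so the step in this assay from compound 1 to compound 3 is expected to stay within the scatter, with no direction implied. Compound 3 is expected to give 1000 nM, within 300 nM to 3000 nM, the expected step being no change at the digits printed from compound 1 to compound 3 (within the scatter).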

Compound 3, inhibition constant: > 1000 nM
Compound 3: a limit, no number; the forecaster's own chance of this, stated with the estimate: 40%; the middle value sits exactly at the limit.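

In this assay trifluoromethyl in place of cyclopropyl on an aromatic carbon, para to a large group, gives a number no lower from compound 1 to compound 3 (the limit leaves the size open) and so brings no gain at this position. Compound 3 stands at a limit and not a number, so the size of the change cannot be read. The series gathers at this limit: the limit of > 1000 nM in this assay, at which 2 of the 3 values shown sit.

Open, from the compounds shown here alone, is whether an amine or a nitrile on this carbon would give a plain number, and on which side of compound 1 it would fall. With one plain value, no trend at this position can be drawn.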